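From Methylsulfonyl to Bromophenylsulfonyl: What to Expect

The source may report more compounds than this note shows. Statements on the series, on what has been measured and on what is new or still open speak of the compounds shown alone.

Measured so far:
compound 1 `CN1CCN(c2ccc(C3=NN(C(=O)c4ccc(F)cc4)C(c4ccc(N(C)C)cc4)C3)cc2)CC1` gives 31.8% in a functional assay on HCC1806 cells (Homo sapiens) for inhibition, read by sulforhodamine B assay, tested at 10 uM; a higher number here means more inhibition at the concentration tested (going by the name of the read-out), a lower number less inhibition
compound 2 `CN1CCN(c2ccc(C3=NN(S(C)(=O)=O)C(c4ccc(N(C)C)cc4)C3)cc2)CC1` gives -18.5% in this assay

Compound 2 stands lowest of the two numbers in this assay. Compound 3 `CN1CCN(c2ccc(C3=NN(S(=O)(=O)c4ccc(Br)cc4)C(c4ccc(N(C)C)cc4)C3)cc2)CC1` is not yet measured; it differs from compound 2 by 4-bromophenyl in place of methyl on a sulfonyl sulfur. Among the compounds with values here, no measured step exchanges methyl for an aromatic ring on a sulfonyl sulfur. Within the data shown here, the only step known, a number 50.3 percentage points lower from compound 1 to compound 2 (beyond the scatter), changed the same ring nitrogen's substituent, moving from an aryl group to methyl. Since compound 3 brings an aryl group back, a rise in this assay is expected, but of uncertain size. Compound 3 is estimated at 10%, with a range from -20% to 40%, which would mean a number 28.5 percentage points higher from compound 2 to compound 3 (beyond the scatter).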

Compound 3, a percentage reported as inhibition, at one concentration (the size of the read-out at that concentration, not a potency): 87.1%
The estimate for compound 3 lay 77.1 percentage points below the measured number; measured number above the stated range.
By their numbers in this assay, from the lowest: compound 2; then compound 1; then compound 3.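

In this assay, the group on the sulfonyl sulfur decides the outcome: 4-bromophenyl in place of methyl gives a number 105.6 percentage points higher from compound 2 to compound 3 (beyond the scatter), so a sulfonyl on the ring nitrogen does not by itself keep the number low. The linking group also counts, since (4-bromophenyl)sulfonyl in place of (4-fluorophenyl)carbonyl gives a number 55.3 percentage points higher from compound 1 to compound 3 (beyond the scatter), although the two groups also differ in their halogen.

From the compounds shown here alone, whether the bromine or the aromatic ring carries the rise remains open, as does the outcome with plain phenyl or 4-methoxyphenyl on that sulfur. Nothing measured here gives a cause for these steps.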